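The source may hold more compounds than are shown below. What is called first, only, known or untested is meant among the compounds shown, and "the series" means these compounds.

In a functional assay on T47D cells (Homo sapiens) for inhibition (on this read-out lower numbers stand for stronger inhibition and higher numbers for weaker inhibition), compound 1, `Oc1ccc(-c2cc(-c3cccc(F)c3)cc(-c3ccccc3O)n2)cc1`, gives only a limit, > 50000 nM. Compound 2, `Oc1ccc(-c2cc(-c3cccc(F)c3)cc(-c3cccc(O)c3)n2)cc1`, differs from it by a 3-hydroxyphenyl in place of a 2-hydroxyphenyl on an aromatic carbon, and in this assay compound 2 gives 3510 nM, so the step of an at least 14-fold lower number from compound 1 to compound 2 (1.15 log units; beyond the scatter) is a large one. Among the measured compounds shown here, compound 3, `Oc1ccc(-c2cc(-c3ccccc3F)cc(-c3ccc(O)cc3)n2)cc1`, gives 15100 nM in this assay; it carries the highest of the two numbers known, with compound 2 nearest to it, and compound 2 differs from compound 3 in two places, so no single step joins them.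

Compound 4, `Oc1ccc(-c2cc(-c3cccc(F)c3)cc(-c3ccc(O)cc3)n2)cc1`, is compound 3 with 3-fluorophenyl in place of 2-fluorophenyl on an aromatic carbon. For the measured compounds named here, the one measured step that bears on such a shift of a substituent from the 2- to the 3-position of a pendant phenyl is an at least 14-fold lower number from compound 1 to compound 2 (1.15 log units; beyond the scatter), though that step moved a hydroxy rather than a fluorine. A lower number is therefore expected for compound 4, and the step of a 4.3-fold lower number from compound 3 to compound 4 (0.63 log units; beyond the scatter) is estimated. Compound 4 is expected to give 3500 nM in this assay, with a range from 900 nM to 14000 nM.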

Compound 4, half-maximal inhibitory concentration: > 50000 nM
Compound 4: only a limit was reported; the forecaster's own chance of this, stated with the estimate: 5%; middle value at least 14-fold (1.15 log units) from the limit.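

Moving the fluorine on the pendant ring opposite the ring nitrogen is not a neutral change, and weakening follows the shift from 2-fluorophenyl to 3-fluorophenyl: an at least 3.3-fold higher number from compound 3 to compound 4 (0.51 log units; beyond the scatter). With 3-fluorophenyl held in place, the position of the hydroxy group also matters, since 4-hydroxyphenyl costs far more than the 3-hydroxyphenyl it replaces: an at least 14-fold higher number from compound 2 to compound 4 (1.15 log units; beyond the scatter). Both steps end at a limit and not at a number, and the step between the other two compounds that stand at this limit cannot be read: the limit of > 50000 nM in this assay, at which 2 of the 4 values shown sit.

As far as these compounds go, it remains open what an amine or a carboxylic acid in place of the fluorine on this ring would give in this assay. Also open, from the compounds shown here alone, is whether the effect of the fluorine shift would hold with 3-hydroxyphenyl in place of 4-hydroxyphenyl.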